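Hydrogen in place of nitro: from compound 3 to compound 4

This account rests on a few compounds, and the source may have more. Where it says the series, first, only, none or still open, it means among the compounds named here.

Numbers so far in a functional assay on A549 cells (Homo sapiens) for inhibition; on this read-out lower numbers stand for stronger inhibition and higher numbers for weaker inhibition:
compound 1 `N#CC1CN1C(=O)Nc1ccc(F)cc1`: 6200 nM
compound 2 `CCOC(=O)c1ccc(NC(=O)N2CC2C#N)cc1`: 2900 nM
compound 3 `N#CC1CN1C(=O)Nc1ccc([N+](=O)[O-])cc1`: 3900 nM

Compound 3 sits second highest of the three numbers, yet both steps to its neighbours fall within the scatter: a 1.3-fold higher number from compound 2 to compound 3 (0.13 log units; within the scatter) and a 1.6-fold lower number from compound 1 to compound 3 (0.20 log units; within the scatter). Within the data shown here, the only step beyond the scatter in this assay is a 2.1-fold lower number from compound 1 to compound 2 (0.33 log units; beyond the scatter), and even that is modest. All three exchanges sit on the same aromatic carbon, and none of them moves a number far.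

Compound 4 `N#CC1CN1C(=O)Nc1ccccc1` is the unsubstituted parent: hydrogen in place of nitro on an aromatic carbon. Among the measured compounds shown here, no measured step removes a group to hydrogen, so the bearing of the three exchanges is indirect. The smallest group measured, fluoro, gives the highest number, compound 1 at 6200 nM, and the nitro of compound 3 lies within the scatter of it. A small rise in the number is therefore expected, a 1.4-fold higher number from compound 3 to compound 4 (0.15 log units; within the scatter), with the spread of the measured steps as the guide. For compound 4 in this assay the estimate is 5500 nM, with a range from 2500 nM to 12000 nM.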

Compound 4, half-maximal inhibitory concentration: 9000 nM
Beside the measured number, compound 4's estimate is 1.6-fold (0.21 log units) below it, and the stated range covers the measured number.
By their numbers in this assay, from the lowest: compounds 2, 3, 1 and 4 (each within the scatter of the next, the first and the last beyond it).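

In this assay, among these compounds, the step of a 2.3-fold higher number from compound 3 to compound 4 (0.36 log units; beyond the scatter) and the step of a 3.1-fold higher number from compound 2 to compound 4 (0.49 log units; beyond the scatter) are the first to show what a substituent at this aromatic carbon is worth against hydrogen: both lie beyond the scatter, though both are modest. Fluoro does not separate from hydrogen, since the step of a 1.5-fold higher number from compound 1 to compound 4 (0.16 log units; within the scatter) stays within the scatter, so the series shows a gain over hydrogen with nitro and ethoxycarbonyl but not with fluoro. Nothing measured here accounts for these differences.

From the compounds shown here alone, whether an amine, a carboxylic acid or a longer ester chain at this carbon would take the number lower than the ethoxycarbonyl of compound 2 remains open. Also open, going by these compounds, is whether nitro or ethoxycarbonyl would give similar steps on another carbon of the ring.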